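The source may hold more compounds than are shown below. What is called first, only, known or untested is meant among the compounds shown, and "the series" means these compounds.

The shared core is carried by compound 1 `CCOC(=O)C1=C(Nc2ccccc2)S/C(=C\c2ccccc2)C1=O` and compound 2 `CCOC(=O)C1=C(Nc2ccccc2)S/C(=C\c2ccc[nH]2)C1=O`. In a functional assay on JAR cells (Homo sapiens) for inhibition, read by MTT assay, with a stated time of 72 h, tested at 10 uM (on this read-out higher numbers stand for more inhibition at the one concentration tested (going by the name of the read-out) and lower numbers for less inhibition), compound 1 gives 20.3%, while compound 2 gives 49.2%, the higher of the two numbers, the step being a number 28.9 percentage points higher from compound 1 to compound 2 (beyond the scatter). Compound 3 `CCOC(=O)C1=C(Nc2ccccc2)S/C(=C\c2cc3cccnc3[nH]2)C1=O` alters the same place: a group of 9 heavy atoms (7 carbon, 2 nitrogen; one five-membered aromatic ring with 1 hetero atom, one six-membered aromatic ring with 1 hetero atom) in place of a group of 5 heavy atoms (4 carbon, 1 nitrogen; one five-membered aromatic ring with 1 hetero atom), on a double-bonded chain carbon bound to a double-bonded ring carbon. Going by the values given here, only that one measured step touches this place, and it exchanged the whole group rather than extending it, so it gives limited guidance; the hydrogen-bond donor on the five-membered aromatic ring is retained. For compound 3 no step beyond the scatter is expected, a number 0.8 percentage points higher from compound 2 to compound 3 (within the scatter), with an estimate of 50% between 25% and 75%.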

Compound 3, a percentage reported as inhibition, at one concentration (the size of the read-out at that concentration, not a potency): 54.3%
The estimate for compound 3 lay 4.3 percentage points below the measured number; the measured number falls inside the stated range.
By their numbers in this assay, from the lowest: compound 1; then compounds 2 and 3 (each within the scatter of the next).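

In this assay, this place, on a double-bonded chain carbon bound to a double-bonded ring carbon, accepts the larger group with a second aromatic ring, with a number 5.1 percentage points higher from compound 2 to compound 3 (within the scatter). Against phenyl, the same group gives a number 34 percentage points higher from compound 1 to compound 3 (beyond the scatter), so compound 2 and compound 3, both with a hydrogen-bond donor on the five-membered aromatic ring, stand apart from compound 1. Nothing available explains these numbers.

As far as these compounds go, whether that hydrogen-bond donor is needed remains open, and 1-methylpyrrol-2-yl in this place would test it. From the compounds shown here alone, the effect of an amine or a carboxylic acid on the larger group is also open.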